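Swapping Bromo for Ethyl on a Quinoline Amide

The compounds below may be only part of what the source reports. "The series", "measured", "known", "first", "only" and "open" are said of these compounds alone.

Measured so far:
- compound 1, `CCN1CCN(c2cc(C)c3cc(NC(=O)c4ccc(Br)cc4)ccc3n2)CC1`: 5940 nM
- compound 2, `Cc1cc(NCCN2CCCCC2)nc2ccc(NC(=O)c3ccc(Cl)c(Cl)c3)cc12`: 1190 nM

In a functional assay on MCF7 cells (Homo sapiens) for antiproliferative activity, read by MTT assay, with a stated time of 72 h (on this read-out lower numbers stand for stronger inhibition and higher numbers for weaker inhibition), compound 1 gives 5940 nM, the highest of the two numbers; compound 2 gives 1190 nM, a lower number, and the gap between them is beyond the scatter. Among the measured compounds shown here, no pair differing in one place has been measured, so no single step has a known size yet.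

Compound 3, `CCc1ccc(C(=O)Nc2ccc3nc(N4CCN(CC)CC4)cc(C)c3c2)cc1`, differs from compound 1 by one change: ethyl in place of bromo on an aromatic carbon. For the measured compounds named here, with no measured step to guide the guess, a step of size a 1.0-fold higher number from compound 1 to compound 3 (0.00 log units; within the scatter) is expected, not beyond the scatter. Compound 3 is therefore estimated at 6000 nM, within a range of 2000 nM to 18000 nM.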

Compound 3, half-maximal inhibitory concentration: 3060 nM
For compound 3 the middle estimate is 2.0-fold (0.29 log units) above the measured one; measured number inside the range.
By their numbers in this assay, from the lowest: compound 2; then compounds 3 and 1 (each within the scatter of the next).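

Putting ethyl where bromo stood on the 4-bromophenyl group gives a 1.9-fold lower number from compound 1 to compound 3 (0.29 log units; within the scatter) in this assay, the first single-place step known for these compounds. At this position, para to a large group, a swap from one heavy atom to two therefore leaves no difference that can be told from ordinary repeat variation. No measurement at hand gives a reason for this result.

Going by these compounds, whether an amine, a carboxylic acid or a longer alkyl chain at this position would give a step beyond the scatter remains open. So does whether ethyl and bromo would also match on a different core, such as that of compound 2.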